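This account rests on a few compounds, and the source may have more. Where it says the series, first, only, none or still open, it means among the compounds named here.

Measured in a functional assay on Jurkat cells (Homo sapiens) for cytotoxicity, with a stated time of 72 h; on this read-out higher numbers stand for an effect only at larger amounts of compound and lower numbers for an effect already at smaller amounts:
- Compound 1 `C=C[C@@](C)(/C=C/c1ccc(O)c(C=O)c1)CCC=C(C)C`: > 49000 nM, a limit
- Compound 2 `C=C[C@@](C)(/C=C/c1ccc(O)c(/C=C/C#N)c1)CCC=C(C)C`: > 49000 nM, a limit
- Compound 3 `C=C[C@@](C)(/C=C/c1ccc(O)c(/C=C/C(N)=O)c1)CCC=C(C)C`: > 49000 nM, a limit

Compound 3 has no number, only the limit > 49000 nM. The whole set shares this position: the limit of > 49000 nM in this assay, at which 3 of the 3 values shown sit.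

Compound 4 `C=C[C@@](C)(/C=C/c1ccc(O)c(/C=C/c2ccc(F)cc2)c1)CCC=C(C)C` differs from compound 3 at a single place: 4-fluorophenyl in place of carbamoyl on a double-bonded chain carbon bound to a double-bonded chain carbon. In short, 4-fluorophenyl stands in place of carbamoyl on a double-bonded chain carbon bound to a double-bonded chain carbon.

Within the data shown here, three measured steps bear on this change: a step that the two limits leave unreadable from compound 2 to compound 3, a step that the two limits leave unreadable from compound 1 to compound 3 and a step that the two limits leave unreadable from compound 1 to compound 2. None of them has a readable size, so they give no measure for the new step. Among the measured compounds shown here, they show only that three different groups in this part of the molecule all left the compounds at the limit in this assay.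

A small shift toward lower numbers is expected, though compound 4 may also report only a limit. The estimated step is an at least 1.4-fold lower number from compound 3 to compound 4 (0.14 log units; that floor lies within the scatter). Compound 4 is expected at about 35000 nM, with an estimated range of 10000 nM to 60000 nM.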

Compound 4, half-maximal effective concentration: > 49000 nM
Compound 4 was reported as a limit (the forecaster's own chance of this, stated with the estimate: 60%); middle value at least 1.4-fold (0.14 log units) from the limit.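

Compound 4 gives only a limit, so its steps from compound 1, compound 2 and compound 3 cannot be read, and all four compounds share one position: the limit of > 49000 nM in this assay, at which 4 of the 4 values shown sit.

The compounds shown leave open whether any group at this place would give a measurable value, and how large that value would be.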